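The compounds below may be only part of what the source reports. "The series", "measured", "known", "first", "only" and "open" are said of these compounds alone.

Measured so far in a functional assay on MIA PaCa-2 cells (Homo sapiens) for antiproliferative activity, read by sulforhodamine B assay, with a stated time of 48 h; on this read-out higher numbers stand for weaker inhibition and lower numbers for stronger inhibition:
compound 1 `COc1ccc(C(=O)/C=C\Nc2ccc(-c3nc4cc(OC)c(OC)c(OC)c4s3)cc2)cc1F` gives 19400 nM
compound 2 `COc1ccc2nc(-c3ccc(N/C=C\C(=O)c4cc(OC)c(OC)c([N+](=O)[O-])c4)c(C)c3)sc2c1` gives 12000 nM
compound 3 `COc1ccc2nc(-c3ccc(N/C=C\C(=O)c4cc(OC)c(OC)c(OC)c4Br)c(C)c3)sc2c1` gives 23400 nM

Among these three numbers compound 3 has the highest one in this assay, but its distance to the others is small: the nearest number is that of compound 1, and even the furthest, that of compound 2, stays within the usual scatter, so no order among the three can be read from them. All three compounds share the same core and differ in the pattern of groups on the aromatic ring of the ketone and on the aniline ring.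

Compound 4 `COc1ccc2nc(-c3ccc(N/C=C\C(=O)c4cc(OC)c(OC)c(OC)c4)c(C)c3)sc2c1` has not yet been measured in this assay. The change from compound 3 to compound 4 is counted as hydrogen in place of bromo on an aromatic carbon. Going by the values given here, no measured pair in this set shows what such a change does in this assay, so there is no directly comparable step to lean on. Given that the three measured compounds sit close together, the step from compound 3 to compound 4 is expected to be modest, if anything toward a lower number, with a 2.3-fold lower number from compound 3 to compound 4 (0.37 log units; beyond the scatter) as the expectation. For compound 4 the estimated value in this assay is 10000 nM, with a range from 2500 nM to 40000 nM.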

Compound 4, half-maximal inhibitory concentration: 10000 nM
The estimate for compound 4 equals the measured number at the digits printed; low and high end bracket the measured number.
By their numbers in this assay, from the lowest: compounds 4, 2, 1 and 3 (each within the scatter of the next, the first and the last beyond it).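

In this assay, going by these compounds alone, the bromo group on the aromatic carbon that is ortho to a large group and ortho to a methoxy group gives the first step that can be read beyond the scatter, with hydrogen in its place: a 2.3-fold lower number from compound 3 to compound 4 (0.37 log units; beyond the scatter). Within the data shown here, this single pair shows that, on this compound, bromo at this place brings no gain over hydrogen, something the three earlier compounds, which shared no one-place step, could not show. The other step, methoxy in place of nitro on an aromatic carbon, is a 1.2-fold lower number from compound 2 to compound 4 (0.08 log units; within the scatter) and lies within the scatter, so the two groups cannot be told apart at that place, and nothing on hand explains either step.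

The compounds shown leave open how an amine, a hydroxyl group or a chloro group on the former bromo carbon would compare with hydrogen and bromo. They also leave open whether the bromo-to-hydrogen step would hold on another core, since compound 1 differs from compound 4 in more than one place and offers no such comparison.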